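Rho kinase 2 series: amide in place of sulfonamide

The compounds below may be only part of what the source reports. "The series", "measured", "known", "first", "only" and "open" are said of these compounds alone.

Measured so far:
compound 1, `COC(=O)c1ccc(C(=O)Nc2cccc(NC(=O)COc3ccc4c(=O)ccoc4c3)c2)cc1`: 29 nM
compound 2, `Cn1ccc(S(=O)(=O)Nc2cccc(NC(=O)COc3ccc4c(=O)ccoc4c3)c2)n1`: 1350 nM

In an assay on isolated protein for inhibition of Rho-associated protein kinase 2 (Homo sapiens), read by scintillation counting, radiometric assay and 33P incorporation, with a stated time of 40 min, in the presence of a further agent that is not named here (a lower number here means a stronger inhibitor, a higher number a weaker inhibitor), compound 2 gives 1350 nM, the higher of the two numbers recorded; compound 1, with 29 nM, sits far lower, and the gap between the two is well beyond the scatter of the method.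

Compound 3, `O=C(COc1ccc2c(=O)ccoc2c1)Nc1cccc(NC(=O)c2ccc(C(=O)O)cc2)c1`, has not yet been measured in this assay. Relative to compound 2 the change is a group of 11 heavy atoms (8 carbon, 3 oxygen; one six-membered aromatic ring of carbon only) in place of a group of 9 heavy atoms (4 carbon, 2 nitrogen, 2 oxygen, 1 sulfur; one five-membered aromatic ring with 2 hetero atoms), on a nitrogen on an aromatic ring. Within the data shown here, no step between measured compounds matches this change exactly, so its size has to be judged from what the two values show. The group that enters in compound 3 closely resembles the corresponding part of compound 1, and compound 1 gives 29 nM, so a large drop in the number, beyond the scatter, is expected on going from compound 2 to compound 3.

For compound 3 the expected value in this assay is 60 nM, with a range of 12 nM to 400 nM. The step that this estimate implies is a 23-fold lower number from compound 2 to compound 3 (1.35 log units; beyond the scatter), and it is expected to be clearly beyond the scatter.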

Compound 3, half-maximal inhibitory concentration: 2030 nM
Estimate against measurement, compound 3: 34-fold (1.53 log units) below; the whole stated range lies below it.
By their numbers in this assay, from the lowest: compound 1; then compounds 2 and 3 (each within the scatter of the next).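

In this assay the methyl on the oxygen next to a carbonyl group proves decisive: hydrogen in its place gives (a 70-fold higher number from compound 1 to compound 3 (1.85 log units; beyond the scatter)), so the low number of compound 1 does not come from the amide-linked benzene ring alone and depends on the methyl ester as a whole. The (4-carboxyphenyl)carbonyl group on a nitrogen on an aromatic ring also cannot be told apart from the group with the five-membered aromatic ring, since the change gives (a 1.5-fold higher number from compound 2 to compound 3 (0.18 log units; within the scatter)), and the two compounds therefore stand together at the weak end of this small set. No measurement bearing on the reason for either step is available here.

Still open, as far as these compounds go, is whether the low number is specific to the methyl ester or also holds with an ethyl ester, a primary amide or a nitrile in place of the carboxylic acid of compound 3. The compounds shown also leave open how a methyl ester would behave on the group with the five-membered aromatic ring, and whether a longer chain between the benzene ring and the ester would be tolerated.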